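Replacing the Amide Hydrogen of Compound 3 with 4-Methoxyphenyl

The source may report more compounds than this note shows. Statements on the series, on what has been measured and on what is new or still open speak of the compounds shown alone.

Among the measured compounds shown here, in a functional assay on ECa-109 cells (Homo sapiens) for antiproliferative activity, read by MTT assay, with a stated time of 48 h (a higher number here means a weaker inhibitor, a lower number a stronger inhibitor), compound 3 `Cn1cc(C2=C(c3nn(CCCN4CCCCC4)c4ncccc34)C(=O)NC2=O)c2ccccc21` gives 42300 nM, the higher of the two numerical values so far. Compound 2 `Cn1cc(C2=C(c3nn(CCCN4CCCCC4)c4ncccc34)C(=O)N(c3cccc4ccccc34)C2=O)c2ccccc21` gives 1830 nM and is its nearest neighbour. Compound 1 `Cn1cc(C2=C(c3nn(CCCN4CCCCC4)c4ncccc34)C(=O)N(c3ccc(Cl)cc3)C2=O)c2ccccc21` gives > 100000 nM, which is a limit of the assay.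

Compound 4 `COc1ccc(N2C(=O)C(c3cn(C)c4ccccc34)=C(c3nn(CCCN4CCCCC4)c4ncccc34)C2=O)cc1` differs from compound 3 at one place, on an amide-type nitrogen in a ring: 4-methoxyphenyl in place of hydrogen on an amide-type nitrogen in a ring. For the measured compounds named here, two measured steps bear on this change, and both end at compound 3, with hydrogen replacing a larger group at that nitrogen. Losing 4-chlorophenyl gives an at least 2.3-fold lower number from compound 1 to compound 3 (0.37 log units; beyond the scatter), whereas losing naphthalen-1-yl gives a 23-fold higher number from compound 2 to compound 3 (1.36 log units; beyond the scatter). These steps point in opposite directions, so a group at this nitrogen can move the number either way. The two groups themselves are separated by an at least 54-fold lower number from compound 1 to compound 2 (1.73 log units; beyond the scatter).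

Of the two, 4-chlorophenyl is the closer match to 4-methoxyphenyl, since both are substituted phenyl groups, but a single pair gives only weak guidance. No shift beyond the scatter is therefore expected, although the uncertainty is wide. The expected change is a 1.4-fold lower number from compound 3 to compound 4 (0.15 log units; within the scatter). For compound 4 the estimated value is 30000 nM, with an expected range from 3000 nM to 100000 nM.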

Compound 4, half-maximal inhibitory concentration: 3340 nM
Compound 4: middle estimate off by 9.0-fold (0.95 log units), on the high side, and the stated range covers the measured number.
By their numbers in this assay, from the lowest: compounds 2 and 4 (each within the scatter of the next); then compound 3. At a limit, above all of these: compound 1.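

In this assay, among the compounds shown here, the new step, a 13-fold lower number from compound 3 to compound 4 (1.10 log units; beyond the scatter), shows that a substituted phenyl group on this amide-type nitrogen can lower the number substantially; among the earlier compounds, only naphthalen-1-yl had done so. The step of a 1.8-fold higher number from compound 2 to compound 4 (0.26 log units; within the scatter) lies within the scatter, so compound 2 and compound 4 cannot be separated, and a large lowering at this nitrogen is therefore not confined to naphthalen-1-yl. The two substituted phenyl compounds also part widely, with methoxy in place of chloro on an aromatic carbon giving an at least 29-fold lower number from compound 1 to compound 4 (1.47 log units; beyond the scatter), a size that is only a bound, as compound 1 stands at a limit: the limit of > 100000 nM in this assay, at which 1 of the 4 values shown sits.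

The compounds shown leave open whether the contrast turns on methoxy or on chloro, since unsubstituted phenyl, 4-methylphenyl and 4-fluorophenyl, which could separate the two readings, are not among them. From the compounds shown here alone, it also remains open whether the methoxy group must stand at the 4-position of the phenyl ring, a question that 3-methoxyphenyl or 2-methoxyphenyl on the same nitrogen would address.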